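Cyano to hydroxy swap on the benzyl ring, two positions

A few compounds are considered here, and "the series" means these few. Any claim that something is new, unique, unknown or untested is made for them only; others in the source may bear on it.

Compound 1 `CN(C)c1ncnc2c1ncn2Cc1ccc(C#N)cc1` and compound 2 `CN(C)c1ncnc2c1ncn2Cc1ccc(O)cc1` share one core and differ by hydroxy in place of cyano on an aromatic carbon. In a functional assay on the whole organism for inhibition, with Rattus norvegicus as the target, in the maximal electroshock model, at a dose of 25 mg/kg by the intraperitoneal route (on this read-out lower numbers stand for less inhibition and higher numbers for more inhibition at the one dose given (going by the name of the read-out)), compound 1 gives 0% and compound 2 gives 0%; the step of no change at the digits printed from compound 1 to compound 2 (within the scatter). Compound 3 `CN(C)c1ncnc2c1ncn2Cc1cccc(C#N)c1` holds the same atoms as compound 1 joined differently; the difference between the two cores is not broken down here. In this assay compound 3 gives 17%, standing above compounds 1 and 2 beyond the scatter. Compound 4 `CN(C)c1ncnc2c1ncn2Cc1cccc(O)c1` is not yet measured and differs from compound 3 by hydroxy in place of cyano on an aromatic carbon. This is the same kind of change as that between compounds 1 and 2, not the same: there the place is para to a large group, here meta to a large group. In this assay, among the compounds with values here, the step is expected to be a number 4 percentage points lower from compound 3 to compound 4 (within the scatter), resting on no change at the digits printed from compound 1 to compound 2 (within the scatter) and on nothing more, since no other pair shows this change. Compound 4 is estimated at 13%, between 0% and 30%.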

Compound 4, a percentage reported as inhibition, in the whole organism at one dose (the size of the read-out at that dose, not a potency): 0%
Compound 4: middle estimate off by 13 percentage points, on the high side; the measured number falls inside the stated range.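

In this assay the swap of cyano for hydroxy does not carry over at equal size from one core to the other: the same change on two cores in this assay, no change at the digits printed (within the scatter) from compound 1 to compound 2 and a number 17 percentage points lower (beyond the scatter) from compound 3 to compound 4, 17 percentage points apart, beyond the scatter of two such steps

On the core of compound 3 the swap reads a number 17 percentage points lower from compound 3 to compound 4 (beyond the scatter), while compound 1 already gives 0%, so the pair on that core leaves no room for a lower number. Two pairs at a single dose therefore show that the step depends on the core here, but they do not show how large the swap would be on a core that starts from a higher number.

Open, from the compounds shown here alone, is whether an amine, a carboxylic acid or a methoxy group in place of the cyano keeps any of the inhibition seen with compound 3.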